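Series notes: from compound 3 to compound 4

The source may report more compounds than this note shows. Statements on the series, on what has been measured and on what is new or still open speak of the compounds shown alone.

Measured so far:
compound 1, `Cc1nc(N2CCC(O)(C3CC3)CC2)nc2ccc(NC(=O)/C=C/c3ccc(C(F)(F)F)cc3)cc12`, 232 nM
compound 2, `COCCC1(O)CCN(c2nc(C)c3cc(NC(=O)/C=C/c4ccc(Cl)cc4)ccc3n2)CC1`, 245 nM
compound 3, `Cc1nc(N2CCC(N3CCOC3=O)CC2)nc2ccc(NC(=O)/C=C/c3ccc(OC(F)(F)F)cc3)cc12`, 41 nM

In an assay on CHO-K1 cells for displacement of a labelled ligand from melanin-concentrating hormone receptor 1 (Homo sapiens), read by scintillation proximity assay, with a stated time of 2 h (a lower number here means a stronger inhibitor, a higher number a weaker inhibitor), compound 3 gives the lowest of the three numbers; its gaps to compound 1 and to compound 2 both lie beyond the scatter, so compound 3 is the strongest of the three measured. Compound 4, `Cc1nc(NCCCNS(C)(=O)=O)nc2ccc(NC(=O)/C=C/c3ccc(OC(F)(F)F)cc3)cc12`, is not yet measured. It differs from compound 3 by (3-(methanesulfonamido)propyl)amino in place of 4-(2-oxo-1,3-oxazolidin-3-yl)piperidin-1-yl on an aromatic carbon. Going by the values given here, no single-point step between measured compounds exists here, so the expectation rests on the structural change alone: a ring-bearing group gives way to an open chain, and a loss beyond the scatter is expected. Compound 4 is expected to give 160 nM, within 45 nM to 600 nM. The expected step is a 3.9-fold higher number from compound 3 to compound 4 (0.59 log units; beyond the scatter).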

Compound 4, half-maximal inhibitory concentration: 54 nM
The estimate for compound 4 lay 3.0-fold (0.47 log units) above the measured number; measured number inside the range.
By their numbers in this assay, from the lowest: compounds 3 and 4 (each within the scatter of the next); then compounds 1 and 2 (each within the scatter of the next).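

In this assay, the aromatic carbon between two ring nitrogen atoms accepts the open-chain (3-(methanesulfonamido)propyl)amino group in place of 4-(2-oxo-1,3-oxazolidin-3-yl)piperidin-1-yl, with a 1.3-fold higher number from compound 3 to compound 4 (0.12 log units; within the scatter). Neither ring of the departing group is therefore needed to keep the number in this range, and the entering chain brings hydrogen-bond donors that the departing group lacks. Nothing available explains why the two groups read alike.

On these data alone, whether the methanesulfonamide matters, or the chain alone suffices, remains open. A propyl chain ending in a hydroxyl or a primary amine, or a longer butyl chain carrying the methanesulfonamide, would separate these.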